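Butyl in place of tert-butyl in compound 3

This account rests on a few compounds, and the source may have more. Where it says the series, first, only, none or still open, it means among the compounds named here.

Compound 1 `O=C(NCc1cc(Cl)ccc1-n1cnnn1)[C@@H]1CC=NN1C(=O)[C@H](O)Cc1ccccc1` gives 11 10^-6 cm/s
Compound 2 `CC(C)(C)[C@@H](O)C(=O)N1N=CC[C@H]1C(=O)NCc1cc(Cl)ccc1-n1cnnn1` gives 15 10^-6 cm/s

In an ADME assay on Caco-2 cells (Homo sapiens) for permeability, read by LC-MS, in the apical to basolateral direction, with a stated time of 60 min, at pH 6.5 (on this read-out lower numbers stand for lower permeability and higher numbers for higher permeability), compound 2 stands within the scatter of compound 1, and neither can be ranked over the other. Compound 3 `CCCC[C@@H](O)C(=O)N1N=CC[C@H]1C(=O)NCc1cc(Cl)ccc1-n1cnnn1` has not yet been measured. Its difference from compound 2 is butyl in place of tert-butyl on a saturated chain carbon bound to a carbonyl carbon and an oxygen on a saturated carbon and in words it is butyl in place of tert-butyl on a saturated chain carbon bound to a carbonyl carbon and an oxygen on a saturated carbon.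

Among the compounds with values here, only one measured step bears on this place, namely a 1.4-fold higher number from compound 1 to compound 2 (0.13 log units; within the scatter) where tert-butyl took the place of benzyl. Within the data shown here, that step stays within the scatter, but it is a single step, and no measured compound carries butyl, so it guides the expectation only loosely. No change beyond the scatter is therefore expected in this assay for this swap. The estimated step is a 1.2-fold lower number from compound 2 to compound 3 (0.06 log units; within the scatter) and it is expected to be lost in the scatter. For compound 3 the expected value is 13 10^-6 cm/s with an estimated range from 6 10^-6 cm/s to 27 10^-6 cm/s on this read-out.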

Compound 3, apparent permeability: 9.8 10^-6 cm/s
Compound 3: the middle estimate sits 1.3-fold (0.12 log units) above what was measured; the measured number falls inside the stated range.
By their numbers in this assay, from the lowest: compounds 3, 1 and 2 (each within the scatter of the next).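

In this assay, butyl in place of tert-butyl, on a saturated chain carbon bound to a carbonyl carbon and an oxygen on a saturated carbon, gives a 1.5-fold lower number from compound 2 to compound 3 (0.18 log units; within the scatter), so the straight and the branched four-carbon groups cannot be told apart on this read-out. Propyl in place of phenyl, on a saturated chain carbon, two bonds along the chain from a carbonyl carbon and an oxygen on a saturated carbon, gives a 1.1-fold lower number from compound 1 to compound 3 (0.05 log units; within the scatter), so benzyl, tert-butyl and butyl at this position now all stand within the scatter of one another, and none can be ranked over the others. Nothing measured here offers a reason why these groups read alike.

The groups shown at this position are all built from carbon and hydrogen alone, so it remains open whether an amine, a carboxylic acid or a much longer chain in their place would give a step beyond the scatter. From the compounds shown here alone, it also remains open whether a methoxy group or an amine in place of the hydroxyl on this same carbon would change the number.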